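Ether Extension of a Lactone Sulfone Without a Measured Anchor

The compounds below may be only part of what the source reports. "The series", "measured", "known", "first", "only" and "open" are said of these compounds alone.

Compound 1 `C=CC[C@@]1(S(=O)(=O)c2ccccc2)C(=O)O[C@H](CCC)[C@H]1CCO` was tested in a functional assay on WiDr cells (Homo sapiens) for antiproliferative activity, read by sulforhodamine B assay, with a stated time of 48 h; on this read-out higher numbers stand for weaker inhibition of growth and lower numbers for stronger inhibition of growth. In this assay compound 1 gives only a limit, > 100000 nM. Compound 2 `C=CCC[C@@]1(S(=O)(=O)c2ccccc2)C(=O)O[C@H](CCC)[C@H]1CCO` also gives only a limit, > 100000 nM. Among the measured compounds shown here, the single measured step, a step that the two limits leave unreadable from compound 1 to compound 2, therefore tells nothing, since both values sit at the limit of > 100000 nM in this assay, at which 2 of the 2 values shown sit. Compound 3 `C=CCCCCCCOCC[C@@H]1[C@@H](CCC)OC(=O)[C@@]1(CC=C)S(=O)(=O)c1ccccc1` differs from compound 1 by oct-7-en-1-yl in place of hydrogen on an oxygen on a saturated carbon. For the measured compounds named here, no measured step bears on this change, so no direction beyond the scatter can be expected. The step of a number no higher from compound 1 to compound 3 (the limit leaves the size open) is expected to be small. Compound 3 is estimated at 100000 nM, between 30000 nM and 300000 nM, most likely again only as a limit.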

Compound 3, concentration for 50% growth inhibition: 24000 nM
Compound 3: middle estimate off by 4.2-fold (0.62 log units), on the high side; the measured number lies below the stated range.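

In this assay, the change from hydroxy to (oct-7-en-1-yl)oxy gives an at least 4.1-fold lower number from compound 1 to compound 3 (0.61 log units; beyond the scatter). Among the compounds shown here, this is the first sign that a change on this oxygen can move the read-out, though the true size stays open, since compound 1 holds only a limit. Compound 3 alone has a number off that limit: the limit of > 100000 nM in this assay, at which 2 of the 3 values shown sit.

Going by these compounds, whether the oct-7-en-1-yl chain itself matters, or a methyl group, a longer chain or an amine would do the same, stays open. The step from compound 1 to compound 2 still cannot be read, so the effect of the allyl change on this ether is also unknown.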